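One More Ring Carbon on the Side Chain

The source may report more compounds than this note shows. Statements on the series, on what has been measured and on what is new or still open speak of the compounds shown alone.

Of the compounds shown here, three sharing a core have been measured in a physicochemical assay for solubility, read by HPLC, in phosphate buffer, measured as kinetic solubility, at pH 7.4 (on this read-out higher numbers stand for higher solubility and lower numbers for lower solubility), so far. Compound 1 `CCC(=O)c1cc(-c2ccc(S(N)(=O)=O)cc2)n(-c2ccc(Cl)cc2)n1` gives 41900 nM here. Compound 2 `CCCC(=O)c1cc(-c2ccc(S(N)(=O)=O)cc2)n(-c2ccc(Cl)cc2)n1` gives 25800 nM here. Compound 3 `NS(=O)(=O)c1ccc(-c2cc(C(=O)CC3CCC3)nn2-c2ccc(Cl)cc2)cc1` gives 4300 nM and holds the lowest number of the three, clearly under both others.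

Compound 4 `NS(=O)(=O)c1ccc(-c2cc(C(=O)CC3CCCC3)nn2-c2ccc(Cl)cc2)cc1` has not been measured yet. It has cyclopentyl in place of cyclobutyl on a saturated chain carbon bound to a carbonyl carbon.

The most useful guides are the measured steps that change the same side chain. Methyl in place of hydrogen gave a 1.6-fold lower number from compound 1 to compound 2 (0.21 log units; within the scatter) and shows no clear change. Cyclobutyl in place of methyl gave a 9.7-fold lower number from compound 1 to compound 3 (0.99 log units; beyond the scatter) as a modest drop. Cyclobutyl in place of ethyl gave a 6.0-fold lower number from compound 2 to compound 3 (0.78 log units; beyond the scatter) as another modest drop.

Going from cyclobutyl to cyclopentyl is a smaller structural change than either of those last two, so a smaller drop is expected in this assay from this single extra ring carbon. The estimated step is a 2.3-fold lower number from compound 3 to compound 4 (0.35 log units; beyond the scatter) and would sit close to the edge of the scatter. The estimate for compound 4 is 1900 nM within an expected range from 700 nM to 5000 nM.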

Compound 4, solubility: 2600 nM
Compound 4: the middle estimate sits 1.4-fold (0.14 log units) below what was measured; low and high end bracket the measured number.
By their numbers in this assay, from the lowest: compounds 4 and 3 (each within the scatter of the next); then compounds 2 and 1 (each within the scatter of the next).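

In this assay, among the compounds shown here, the step from cyclobutyl to cyclopentyl on a saturated chain carbon bound to a carbonyl carbon gives a 1.7-fold lower number from compound 3 to compound 4 (0.22 log units; within the scatter), so this added ring carbon brings no clear change, unlike the earlier steps from the open chains to cyclobutyl. The open-chain comparisons are beyond the scatter, with a 9.9-fold lower number from compound 2 to compound 4 (1.00 log units; beyond the scatter) and a 16-fold lower number from compound 1 to compound 4 (1.21 log units; beyond the scatter), so among these four compounds, compound 3 and compound 4, with their rings, form one group under compound 1 and compound 2, and no compound goes against this split. Nothing available here gives a reason for either the flat ring step or the gap to the open chains.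

The compounds shown leave open whether a larger ring such as cyclohexyl would stay level with compound 3 and compound 4 or fall further, and how an amine or a carboxylic acid on the side chain would read in this assay. A longer open chain such as pentyl would also test whether the split follows the presence of a ring or simply the size of the side chain.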